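The source may hold more compounds than are shown below. What is called first, only, known or untested is meant among the compounds shown, and "the series" means these compounds.

In a functional assay on K562 cells (Homo sapiens) for cytotoxicity, read by MTT assay, with a stated time of 48 h (on this read-out lower numbers stand for stronger inhibition and higher numbers for weaker inhibition), the compounds measured so far read:

Compound 1 `CNC(=O)CC[C@H](NS(=O)(=O)c1ccc([N+](=O)[O-])cc1)C(=O)O`: > 500000 nM
Compound 2 `CCCCNC(=O)CC[C@H](NS(=O)(=O)c1ccc([N+](=O)[O-])cc1)C(=O)O`: 19700 nM
Compound 3 `CC(C)CNC(=O)CC[C@H](NS(=O)(=O)c1ccc([N+](=O)[O-])cc1)C(=O)O`: 42500 nM

The entry for compound 1 is a limit of the assay and not a number. Of the two true numbers, compound 3 holds the higher, and compound 2 lies nearest to it. Compound 4 `O=C(CC[C@H](NS(=O)(=O)c1ccc([N+](=O)[O-])cc1)C(=O)O)NCc1ccccc1` differs from compound 3 as follows: phenyl in place of isopropyl on a saturated chain carbon bound to an amide-type nitrogen.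

Two large steps, an at least 25-fold lower number from compound 1 to compound 2 (1.40 log units; beyond the scatter) and an at least 11-fold lower number from compound 1 to compound 3 (1.07 log units; beyond the scatter), both start from the limit and so fix only a minimum size. The closer guide is a 2.2-fold higher number from compound 2 to compound 3 (0.33 log units; beyond the scatter), a modest swap at the same place. A step of similar modest size is therefore expected in this assay, with a slight lean towards a lower number. The expected step is a 1.7-fold lower number from compound 3 to compound 4 (0.23 log units; within the scatter). For compound 4 the estimated value is 25000 nM, with an expected range from 9000 nM to 70000 nM.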

Compound 4, half-maximal inhibitory concentration: 23400 nM
Compound 4: middle estimate off by 1.1-fold (0.03 log units), on the high side; the range from low to high includes it.
By their numbers in this assay, from the lowest: compounds 2, 4 and 3 (each within the scatter of the next, the first and the last beyond it). At a limit, above all of these: compound 1.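

In this assay the benzylamino group, with its six-membered aromatic ring of carbon only, takes the place of the open chains and the read-out stays within the scatter of both: the data give a 1.8-fold lower number from compound 3 to compound 4 (0.26 log units; within the scatter) and also a 1.2-fold higher number from compound 2 to compound 4 (0.07 log units; within the scatter) in the same comparison. So, among these compounds, this place on a saturated chain carbon bound to an amide-type nitrogen accepts a ring as well as a branched or unbranched chain, although compound 2 and compound 3 themselves lie beyond the scatter of each other. Compound 1 stays a limit and not a number, so an at least 21-fold lower number from compound 1 to compound 4 (1.32 log units; beyond the scatter) fixes only a minimum size: the limit of > 500000 nM in this assay, at which 1 of the 4 values shown sits.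

From the compounds shown here alone, whether an amine, a carboxylic acid or a longer chain at this place would hold the read-out in the same range remains open. So does what a chloro or methoxy group on the phenyl ring of compound 4 would do.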